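Fluoro for methoxy: from compound 2 to compound 4

The source may hold more compounds than are shown below. What is called first, only, known or untested is meant among the compounds shown, and "the series" means these compounds.

Measured so far:
- compound 1 `COc1ccc(CCC[C@@H]2C[C@@H]([C@@H](O)c3ccc(OC)c(OC)c3)CO[C@H]2c2ccc(OC)c(OC)c2)cc1OC`, in a functional assay on HeLa cells (Homo sapiens) for cytotoxicity, read by WST assay, with a stated time of 48 h (on this read-out higher numbers stand for weaker inhibition and lower numbers for stronger inhibition), compound 1 gives 35700 nM
- compound 2 `COc1ccccc1/C=C/C[C@H]1C[C@@H]([C@@H](O)c2ccccc2)CO[C@@H]1c1ccccc1`, in this assay compound 2 gives 14700 nM
- compound 3 `COc1ccc(/C=C/C[C@H]2C[C@@H]([C@@H](O)c3ccc(OC)c(OC)c3)CO[C@@H]2c2ccccc2)cc1OC`, in this assay compound 3 gives 17000 nM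

Compound 2 holds the lowest of the three numbers in this assay. Compound 3 lies within the scatter of it, so no order between these two is claimed; compound 1 stands beyond the scatter above compound 2. Compound 4 `O[C@@H](c1ccccc1)[C@H]1CO[C@H](c2ccccc2)[C@@H](C/C=C/c2ccccc2F)C1` is not yet measured. It differs from compound 2 in one place: fluoro in place of methoxy on an aromatic carbon. Among the compounds with values here, no pair of measured compounds isolates this change, so its size is unknown from the series. The step from compound 2 to compound 4 is expected to be a 1.0-fold higher number from compound 2 to compound 4 (0.01 log units; within the scatter), with no direction beyond the scatter. Compound 4 is estimated at 15000 nM, range 6000 nM to 40000 nM.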

Compound 4, half-maximal inhibitory concentration: 9730 nM
Beside the measured number, compound 4's estimate is 1.5-fold (0.19 log units) above it; low and high end bracket the measured number.
By their numbers in this assay, from the lowest: compounds 4, 2 and 3 (each within the scatter of the next); then compound 1.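

Within the data shown here, this is the first pair that isolates a change at this position: this assay gives a 1.5-fold lower number from compound 2 to compound 4 (0.18 log units; within the scatter) for fluoro in place of methoxy on an aromatic carbon. The 2-methoxyphenyl group can therefore be exchanged for 2-fluorophenyl without a step beyond the scatter, so the methoxy oxygen and carbon are not needed to hold the number in this range. Nothing on hand explains the size of this step.

Still open, on these data alone, is whether a chloro, an amine or a carboxylic acid on this carbon would give a step beyond the scatter.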